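Thiosemicarbazide series: cyclic amine swap on the thiocarbonyl

This account rests on a few compounds, and the source may have more. Where it says the series, first, only, none or still open, it means among the compounds named here.

Compound 1 `N/C(=N\NC(=S)N1CCCC1)c1ccc(F)cn1` holds the second of three numbers in a functional assay on A-375 cells (Homo sapiens) for cytotoxicity, read by MTT assay, with a stated time of 72 h, tested at 30 uM (a higher number here means more inhibition of growth at the concentration tested, a lower number less inhibition of growth), where compound 1 gives 83.2%. Compound 3 `Cc1ccnc(/C(N)=N/NC(=S)N2CCSCC2)c1` gives 84.9%, and compound 2 `Cc1ccnc(/C(N)=N/NC(=S)N2CCN(c3ccccn3)CC2)c1` gives 79.4%; both numbers lie within the scatter of the number for compound 1, so the three compounds cannot be told apart on these data. Compound 4 `N/C(=N\NC(=S)N1CCOCC1)c1ccc(F)cn1` differs from compound 1 by morpholin-4-yl in place of pyrrolidin-1-yl on a thiocarbonyl carbon. Going by the values given here, no pair of measured compounds shows this change, and the three measured numbers in this assay hardly differ, so a step within the scatter, in either direction, is expected: a number 3.2 percentage points lower from compound 1 to compound 4 (within the scatter). For compound 4 the expected value in this assay is 80%, with a range from 64% to 92%.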

Compound 4, percent growth inhibition at one concentration: 85.9%
For compound 4 the middle estimate is 5.9 percentage points below the measured one; low and high end bracket the measured number.
By their numbers in this assay, from the lowest: compounds 2, 1, 3 and 4 (each within the scatter of the next).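

In this assay, morpholin-4-yl in place of pyrrolidin-1-yl on a thiocarbonyl carbon gives a number 2.7 percentage points higher from compound 1 to compound 4 (within the scatter), the first step read directly at this position. The six-membered ring with its added oxygen therefore leaves the number indistinguishable from that of the five-membered ring on the shared core. No supporting data bear on this result.

Going by these compounds, whether any replacement at this position gives a step beyond the scatter remains open. So does the outcome for an open-chain group such as dimethylamino on the same carbon.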